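Amide nitrogen substituent change from compound 1 to compound 4

This account rests on a few compounds, and the source may have more. Where it says the series, first, only, none or still open, it means among the compounds named here.

Among the measured compounds shown here, compound 1 `CCOC(=O)[C@]1(C(=O)Nc2ccccc2Cl)C[C@@H]1c1cc(OC)c(OC)c(OC)c1` is the one compound of the series with a plain number in a functional assay on K562 cells (Homo sapiens) for cytotoxicity, read by MTT assay, with a stated time of 48 h; a higher number here means a weaker inhibitor, a lower number a stronger inhibitor: compound 1 gives 19500 nM. Its mirror image, compound 2 `CCOC(=O)[C@@]1(C(=O)Nc2ccccc2Cl)C[C@H]1c1cc(OC)c(OC)c(OC)c1`, reaches only the limit of the measurement in this assay, compound 2 giving > 100000 nM. That is a step of an at least 5.1-fold higher number from compound 1 to compound 2 (0.70 log units; beyond the scatter), and the two structures differ only in configuration as drawn (the fact that compounds 1 and 2 differ only in the configuration as drawn). Compound 3 `CCOC(=O)C1(C(=O)Nc2ccccc2Cl)CC1c1cc(OC)c(OC)c(OC)c1`, drawn without defined configuration, has two entries in this assay, compound 3 giving 41400 nM; 14200 nM (2 entries), which spread across the scatter (the several entries of compound 3 in this assay, 41400 nM; 14200 nM (2 entries)). Compound 1 and compound 3 differ in whether a configuration is drawn (the fact that one of compounds 1 and 3 is drawn with a defined configuration and the other without, at the place where they differ), as do compound 2 and compound 3 (the fact that one of compounds 2 and 3 is drawn with a defined configuration and the other without, at the place where they differ).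

Compound 4 `CCOC(=O)[C@]1(C(=O)NCc2ccc(C)cc2)C[C@@H]1c1cc(OC)c(OC)c(OC)c1` keeps the configuration of compound 1 and changes the amide: 4-methylbenzyl in place of 2-chlorophenyl on an amide-type nitrogen. For the measured compounds named here, no measured step touches this amide-type nitrogen; the only step measured is the inversion of the configuration. The expectation for compound 4 therefore rests on compound 1 alone, with no direction given, so a step of a 1.3-fold higher number from compound 1 to compound 4 (0.11 log units; within the scatter) is expected, within the scatter. Compound 4 is estimated at 25000 nM, between 7000 nM and 90000 nM.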

Compound 4, half-maximal inhibitory concentration: 20400 nM
Compound 4: the middle estimate sits 1.2-fold (0.09 log units) above what was measured, within the range that was stated.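

In this assay, the amide-type nitrogen now has its first measured step, with 4-methylbenzyl in place of 2-chlorophenyl giving a 1.0-fold higher number from compound 1 to compound 4 (0.02 log units; within the scatter). Among the compounds shown here, with the configuration of compound 1 kept, these two substituents are not separated by this assay, whereas the only earlier step, the inversion of configuration, lay beyond the scatter; the amide substituent can therefore differ in this way with no readable effect on the number. Nothing available accounts for this flat step.

The exchange alters the chlorine, the methyl and the carbon link to the nitrogen all at once, so their separate contributions cannot be read. Also open, as far as these compounds go, is whether a non-aromatic substituent on this nitrogen, such as cyclohexyl or 2-aminoethyl, would stay level with compound 1.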